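This account rests on a few compounds, and the source may have more. Where it says the series, first, only, none or still open, it means among the compounds named here.

Measured compounds:
- compound 1, `Cc1nc(C(NC(=O)C(=O)Nc2ccc(F)cc2F)C2CCCCN2)sc1CO`, in an ADME assay on MT2 cells (Homo sapiens) for cytotoxicity, read by XTT assay, with a stated time of 4 days; a lower number here means that less compound is tolerated, a higher number that more compound is tolerated: > 110000 nM
- compound 2, `Cc1ccc(NC(=O)C(=O)NC(c2nc(C)c(CCO)s2)C2CCCCN2)c(F)c1`, in this assay: > 78800 nM

Compound 1 has only a limit in this assay, the value > 110000 nM, so no number is known for it. Compound 2 likewise reaches only a limit in this assay, the value > 78800 nM. Neither of the two values shown is a number that can be placed against the other, and both sit at the limits of their measurements, as the lines the limit of > 110000 nM in this assay, at which 1 of the 2 values shown sits, and the limit of > 78800 nM in this assay, at which 1 of the 2 values shown sits, record. Compound 1 therefore stands at the limit and cannot be ranked.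

Compound 3, `Cc1nc(C(NC(=O)C(=O)NC2CCCCCC2)C2CCCCN2)sc1CO`, has not yet been measured in this assay. It differs from compound 1 in a single place: cycloheptyl in place of 2,4-difluorophenyl on an amide-type nitrogen. For the measured compounds named here, no step between measured compounds is available to gauge this change, so no direction can be drawn from the data. The expectation for compound 3 is that it stays at or near the limit, with a step of a number no higher from compound 1 to compound 3 (the limit leaves the size open) that is not expected to go beyond the usual scatter. Compound 3 is estimated at 110000 nM, within a range from 40000 nM to 300000 nM, with the assay most likely reporting only a limit again.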

Compound 3, half-maximal cytotoxic concentration: > 90000 nM
Compound 3 gave a limit, no number; the forecaster's own chance of this, stated with the estimate: 70%; the middle value lies beyond the limit too.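

In this assay compound 3 gives the limit > 90000 nM and no number. Compound 1 likewise has only the limit > 110000 nM and no number, so no step can be read between compound 1 and compound 3. The compounds shown leave open at what concentration any of them would become cytotoxic, and whether exchanging 2,4-difluorophenyl for cycloheptyl changes that concentration.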